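The source may hold more compounds than are shown below. What is called first, only, known or untested is meant among the compounds shown, and "the series" means these compounds.

Measured compounds:
compound 1, `N=C(NO)NS(=O)(=O)c1cc(-c2nnc(-c3ccc(Cl)cc3)s2)c(Cl)cc1SCc1ccccc1`, 1960 nM
compound 2, `COc1cc(CSc2cc(Cl)c(-c3nc(-c4ccccc4)no3)cc2S(=O)(=O)NC(=N)NO)cc(OC)c1OC`, 13500 nM
compound 3, `N=C(NO)NS(=O)(=O)c1cc(-c2nc(-c3ccccc3)no2)c(Cl)cc1SCc1ccccc1`, 1800 nM

In a functional assay on Malme-3M cells (Homo sapiens) (a lower number here means a stronger inhibitor of growth, a higher number a weaker inhibitor of growth), compound 2 gives the highest of the three numbers, so it is the weakest growth inhibitor among them; compound 1 gives 1960 nM and compound 3 gives 1800 nM. Among the measured compounds shown here, the one measured step touching compound 2 is a 7.5-fold lower number from compound 2 to compound 3 (0.88 log units; beyond the scatter), a change on the other side of the shared core. Compound 4, `COc1cc(CSc2cc(Cl)c(-c3nc(-c4ccc(Cl)cc4)no3)cc2S(=O)(=O)NC(=N)NO)cc(OC)c1OC`, differs from compound 2 by chloro in place of hydrogen on an aromatic carbon. For the measured compounds named here, no measured pair isolates this change. The nearest hint comes from compound 1 and compound 3, which differ in more than one place, among them the same chloro group on the outer ring, and whose values in this assay lie within the usual scatter of each other. On that slender basis, the change from compound 2 to compound 4 is expected to give a 1.1-fold lower number from compound 2 to compound 4 (0.05 log units; within the scatter), that is, no step beyond the scatter. Compound 4 is therefore estimated at 12000 nM, with a likely range from 5000 nM to 30000 nM.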

Compound 4, concentration for 50% growth inhibition: 7760 nM
For compound 4 the middle estimate is 1.5-fold (0.19 log units) above the measured one; the range from low to high includes it.
By their numbers in this assay, from the lowest: compounds 3 and 1 (each within the scatter of the next); then compounds 4 and 2 (each within the scatter of the next).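

In this assay, among the compounds shown here, chloro in place of hydrogen on the six-membered aromatic ring, para to a large group, gives a 1.7-fold lower number from compound 2 to compound 4 (0.24 log units; within the scatter), the first reading of this change with nothing else altered. This position therefore takes a chloro without a step beyond the scatter, at least with the 3,4,5-trimethoxyphenyl group on the sulfur side, whereas the change on that side gives a 7.5-fold lower number from compound 2 to compound 3 (0.88 log units; beyond the scatter) and does go beyond it. No measurement is offered here that could explain this result.

The compounds shown leave open whether the chloro would read the same with plain phenyl in place of 3,4,5-trimethoxyphenyl on the sulfur side. They also leave open how a methoxy group, an amine or a carboxylic acid would fare at this same ring position.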